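A side-chain swap on a compound at the assay limit

The compounds below may be only part of what the source reports. "The series", "measured", "known", "first", "only" and "open" are said of these compounds alone.

Measured so far in a functional assay on BXPC-3 cells (Homo sapiens) for antiproliferative activity, read by MTT assay, with a stated time of 24 h; a higher number here means a weaker inhibitor, a lower number a stronger inhibitor:
- Compound 1 `CCn1c(C(=O)NCCC(=O)OC)ccc1C(CC)(CC)c1ccc(OCS(=O)(=O)c2ccccc2)c(C)c1`: > 50000 nM (a limit)
- Compound 2 `CCn1c(C(=O)N[C@@H](CO)CCO)ccc1C(CC)(CC)c1ccc(OCS(=O)(=O)c2ccccc2)c(C)c1`: > 50000 nM (a limit)

Compound 2 gives no number in this assay, only the limit > 50000 nM. The evidence so far is the limit of > 50000 nM in this assay, at which 2 of the 2 values shown sit. Going by the values given here, the one measured step is a step that the two limits leave unreadable from compound 1 to compound 2, so it offers no size to carry forward.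

Compound 3 `CCn1c(C(=O)N[C@@H](C(=O)O)C(C)C)ccc1C(CC)(CC)c1ccc(OCS(=O)(=O)c2ccccc2)c(C)c1` keeps the shared core and changes only the group on the amide-type nitrogen: 1-carboxy-2-methylpropyl in place of 3-hydroxy-1-(hydroxymethyl)propyl on an amide-type nitrogen. A 1-carboxy-2-methylpropyl group thus takes the place of 3-hydroxy-1-(hydroxymethyl)propyl.

With no measured number to work from, the expectation rests on (the limit of > 50000 nM in this assay, at which 2 of the 2 values shown sit), and compound 3 may well return only a limit too. No change beyond the usual scatter is expected, and the estimated size is a number no higher from compound 2 to compound 3 (the limit leaves the size open). For compound 3 the estimate is 50000 nM, with an expected range from 15000 nM to 120000 nM.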

Compound 3, half-maximal inhibitory concentration: 13900 nM
For compound 3 the middle estimate is 3.6-fold (0.56 log units) above the measured one; measured number below the stated range.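

The group on the amide-type nitrogen can bring this core to a readable number in this assay: 1-carboxy-2-methylpropyl in place of 3-hydroxy-1-(hydroxymethyl)propyl gives an at least 3.5-fold lower number from compound 2 to compound 3 (0.55 log units; beyond the scatter). Measured against 2-(methoxycarbonyl)ethyl, the same group gives an at least 3.5-fold lower number from compound 1 to compound 3 (0.55 log units; beyond the scatter). Both steps give only a minimum size, since each starts from a compound that reports a limit and not a number: the limit of > 50000 nM in this assay, at which 2 of the 3 values shown sit.

Going by these compounds, whether the carboxy part or the branched 2-methylpropyl part of the new group matters more stays open, as the two parts enter together. The methyl ester of the 1-carboxy-2-methylpropyl group, or a 1-carboxyethyl group, would pull these two parts apart.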